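Swapping the Indazole for a Benzofuran: Solubility Outlook

A few compounds are considered here, and "the series" means these few. Any claim that something is new, unique, unknown or untested is made for them only; others in the source may bear on it.

Of the compounds shown here, three built on one shared core have been measured in a physicochemical assay for solubility, read by HPLC, in simulated intestinal fluid, with a stated time of 16 h, tested at 125 ug/mL; on this read-out higher numbers stand for higher solubility and lower numbers for lower solubility. Compound 1 `CNC(=O)c1cc(C(=O)NC2CC2)cn(Cc2cccc3cc[nH]c23)c1=O` gives 11 ug/mL. Compound 2 `CNC(=O)c1cc(C(=O)NC2CC2)cn([C@H](C)c2ccccc2)c1=O` gives 815 ug/mL. Compound 3 `CNC(=O)c1cc(C(=O)NC2CC2)cn(Cc2cccc3cn[nH]c23)c1=O` gives 131 ug/mL, which places compound 3 second highest of the three, below compound 2 and well above compound 1. The only single-point step among these is a 12-fold higher number from compound 1 to compound 3 (1.08 log units; beyond the scatter), so the change of one fused bicyclic group for another has so far moved this assay by a large amount.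

Compound 4 `CNC(=O)c1cc(C(=O)NC2CC2)cn(Cc2cccc3occc23)c1=O` has not yet been measured. It differs from compound 3 in one place: 1-benzofuran-4-yl in place of 1H-indazol-7-yl on a saturated chain carbon bound to an aromatic nitrogen. Within the data shown here, the group that enters carries no hydrogen-bond donor, whereas the one that leaves carries one, and the only measured step at this position, a 12-fold higher number from compound 1 to compound 3 (1.08 log units; beyond the scatter), shows that exchanging one such bicyclic group for another can shift the read-out well beyond the scatter. Among the measured compounds shown here, no measured pair tells how a benzofuran compares with an indazole here, so the direction is uncertain; on balance a drop toward the value of compound 1 seems more likely than a rise. Compound 4 is therefore expected to give 25 ug/mL, between 5 ug/mL and 120 ug/mL, an estimated step of a 5.2-fold lower number from compound 3 to compound 4 (0.72 log units; beyond the scatter).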

Compound 4, solubility: 74 ug/mL
For compound 4 the middle estimate is 3.0-fold (0.47 log units) below the measured one; the range from low to high includes it.
By their numbers in this assay, from the lowest: compound 1; then compounds 4 and 3 (each within the scatter of the next); then compound 2.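

In this assay the exchange of 1H-indazol-7-yl for 1-benzofuran-4-yl on the saturated chain carbon gives a 1.8-fold lower number from compound 3 to compound 4 (0.25 log units; within the scatter), so these two groups cannot be told apart on this read-out, even though the entering group has 0 hydrogen-bond donors and the leaving group has 1. Set against the indole, the same benzofuran gives a 6.7-fold higher number from compound 1 to compound 4 (0.83 log units; beyond the scatter), which means that the low number of compound 1 is not shared by either of the other two fused groups at this place. No further measurement is available that would explain why the indole stands apart from these two groups.

A plain benzyl group at this place, or a fused group bearing an amine or a carboxylic acid, would show whether another group can approach compound 2 at 815 ug/mL in this assay. Going by these compounds, the rest of the molecule is the same in compounds 1, 3 and 4, so it remains open whether these steps would keep their size if the cyclopropyl amide were replaced by a longer chain.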